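Chloro to bromo exchange: estimating compound 4

The source may report more compounds than this note shows. Statements on the series, on what has been measured and on what is new or still open speak of the compounds shown alone.

Measured so far in an assay on isolated protein for inhibition of Tryptophan 2,3-dioxygenase (Homo sapiens), read by spectrophotometry, with a stated time of 1 h; on this read-out higher numbers stand for weaker inhibition and lower numbers for stronger inhibition:
compound 1 `O=[N+]([O-])c1ccc(N/C(=N\O)c2ccccc2Br)c2nonc12` gives 25000 nM
compound 2 `O=[N+]([O-])c1ccc(N/C(=N\O)c2ccc(F)cc2)c2nonc12` gives 21000 nM
compound 3 `O=[N+]([O-])c1ccc(N/C(=N\O)c2ccc(Cl)cc2)c2nonc12` gives 40000 nM

Compound 3 sits with the other two numbers rather than apart from them: the step of a 1.6-fold higher number from compound 1 to compound 3 (0.20 log units; within the scatter) and the step of a 1.9-fold higher number from compound 2 to compound 3 (0.28 log units; within the scatter) are both within the scatter, so no ranking of the three is supported.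

Compound 4 `O=[N+]([O-])c1ccc(N/C(=N\O)c2ccc(Br)cc2)c2nonc12` differs from compound 3 in one place: bromo in place of chloro on an aromatic carbon. The step that bears on this is the halogen swap at the same aromatic carbon, a 1.9-fold higher number from compound 2 to compound 3 (0.28 log units; within the scatter), which stayed within the scatter. The other halogen swaps seen, a 1.2-fold lower number from compound 1 to compound 2 (0.08 log units; within the scatter) and a 1.6-fold higher number from compound 1 to compound 3 (0.20 log units; within the scatter), also stayed within the scatter. Going by the values given here, nothing among the measured compounds suggests that moving from chloro to bromo should change the read-out in this assay more than these did.

Compound 4 is therefore expected to give about 40000 nM in this assay, with a range of 18000 nM to 90000 nM. The step this estimate means, no change at the digits printed from compound 3 to compound 4 (within the scatter), is expected to be none beyond the scatter.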

Compound 4, half-maximal inhibitory concentration: 50000 nM
Compound 4: middle estimate off by 1.3-fold (0.10 log units), on the low side; the range from low to high includes it.
By their numbers in this assay, from the lowest: compounds 2, 1, 3 and 4 (each within the scatter of the next, the first and the last beyond it).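

In this assay, the change from 4-chlorophenyl to 4-bromophenyl gives a 1.3-fold higher number from compound 3 to compound 4 (0.10 log units; within the scatter), so chloro and bromo cannot be told apart at this aromatic carbon. Comparing the same carbon with fluoro gives a 2.4-fold higher number from compound 2 to compound 4 (0.38 log units; beyond the scatter) as the first step in the series to pass the scatter, though it is modest and the fluoro-to-chloro step there stayed within it. The bromo group placed as in 4-bromophenyl rather than 2-bromophenyl gives a 2.0-fold higher number from compound 1 to compound 4 (0.30 log units; within the scatter), which supports no preference between those two groups, and no supporting data account for any of these steps.

As far as these compounds go, whether an amine or a carboxylic acid on this aromatic carbon would give a larger step than the halogens remains open. Also open, from the compounds shown here alone, is how far changes to the shared core would move the read-out.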